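The source may report more compounds than this note shows. Statements on the series, on what has been measured and on what is new or still open speak of the compounds shown alone.

In a functional assay on SK-BR-3 cells (Homo sapiens) for antiproliferative activity, read by MTT assay, with a stated time of 72 h (a lower number here means a stronger inhibitor, a higher number a weaker inhibitor), the measured compounds are:
Compound 1 `C/C=C1/[C@H](O[C@@H]2O[C@H](CO)[C@@H](O)[C@H](O)[C@H]2O)OC=C(C(=O)OC)[C@H]1CC(=O)OCc1ccco1` with > 15000 nM as a limit
Compound 2 `C/C=C1/[C@H](O[C@@H]2O[C@H](CO)[C@@H](O)[C@H](O)[C@H]2O)OC=C(C(=O)OC)[C@H]1CC(=O)NCCC` with > 20000 nM as a limit
Compound 3 `C/C=C1/[C@H](O[C@@H]2O[C@H](CO)[C@@H](O)[C@H](O)[C@H]2O)OC=C(C(=O)OC)[C@H]1CC(=O)OCCC` with > 15000 nM as a limit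

Compound 3 has no number of its own, only the limit > 15000 nM as its standing. The change to compound 4 `C/C=C1/[C@H](O[C@@H]2O[C@H](CO)[C@@H](O)[C@H](O)[C@H]2O)OC=C(C(=O)OC)[C@H]1CC(=O)OCCc1ccc([N+](=O)[O-])cc1` is 4-nitrophenyl in place of methyl on a saturated chain carbon, two bonds along the chain from an oxygen next to a carbonyl group and, cut one bond further out, reads propyl to 2-(4-nitrophenyl)ethyl. The measured changes nearest to it are a step that the two limits leave unreadable from compound 1 to compound 3 and a step that the two limits leave unreadable from compound 2 to compound 3 and neither gives a size to carry over. No direction follows from them, so only a small change is expected, given as a step that the limit leaves unreadable from compound 3 to compound 4 and resting on no size taken from them. Compound 4 is expected at 18000 nM with 5000 nM to 50000 nM as its estimated range.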

Compound 4, half-maximal inhibitory concentration: > 20000 nM
Compound 4 gave a limit, no number; the forecaster's own chance of this, stated with the estimate: 70%; middle value at least 1.1-fold (0.04 log units) from the limit.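

In this assay, compound 4 gives only a limit, as do compound 1, compound 2 and compound 3, so no step among these compounds can be read. The compounds shown leave open whether any of these groups on the carbonyl carbon changes the antiproliferative activity at all.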